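The compounds below may be only part of what the source reports. "The series", "measured", "known", "first", "only" and "open" are said of these compounds alone.

In a functional assay on T47D cells (Homo sapiens) for cytotoxicity, read by MTT assay, with a stated time of 24 h (on this read-out higher numbers stand for weaker inhibition and lower numbers for stronger inhibition), compound 1 `COc1ccc(/C=C\C(=O)O)c(OCc2cn(-c3ccccc3F)nn2)c1CC=C(C)C` gives 11000 nM. On the three numbers at hand it stands at one end, with compound 3 `COc1ccc(/C=C\C(=O)O)c(OCc2cn(-c3cccc(C#N)c3)nn2)c1CC=C(C)C` nearest at 19200 nM and compound 2 `COc1cccc(-n2cc(COc3c(/C=C\C(=O)O)ccc(OC)c3CC=C(C)C)nn2)c1` furthest at 20400 nM, both separated from compound 1 only within the scatter. The measured steps all swap the substituent on the phenyl attached to the aromatic nitrogen: a 1.9-fold higher number from compound 1 to compound 2 (0.27 log units; within the scatter), a 1.7-fold higher number from compound 1 to compound 3 (0.24 log units; within the scatter) and a 1.1-fold lower number from compound 2 to compound 3 (0.03 log units; within the scatter). Compound 4 `COc1ccc(/C=C\C(=O)O)c(OCc2cn(-c3ccccc3C(=O)N3CCC(O)C3)nn2)c1CC=C(C)C` differs from compound 1 by (3-hydroxypyrrolidin-1-yl)carbonyl in place of fluoro on an aromatic carbon. For the measured compounds named here, the change keeps the same point of variation as the measured steps, so those steps bear on it, and each of them stayed within the scatter; the entering group is larger than anything tried here, and no measured compound shows what a group of this kind does. Compound 4 is therefore expected to move by a 1.2-fold higher number from compound 1 to compound 4 (0.07 log units; within the scatter) in this assay, no step beyond the scatter in either direction. The estimate for compound 4 is 13000 nM, in a range from 5000 nM to 35000 nM.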

Compound 4, half-maximal inhibitory concentration: 13400 nM
Compound 4: the middle estimate sits 1.0-fold (0.01 log units) below what was measured; measured number inside the range.
By their numbers in this assay, from the lowest: compounds 1, 4, 3 and 2 (each within the scatter of the next).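

In this assay, putting (3-hydroxypyrrolidin-1-yl)carbonyl in place of fluoro on an aromatic carbon, ortho to a large group, gives a 1.2-fold higher number from compound 1 to compound 4 (0.09 log units; within the scatter). The earlier steps shown here exchanged only fluoro, methoxy and cyano-bearing aryl groups, whereas this one brings in a five-membered non-aromatic ring, a double bond outside aromatic rings and a hydrogen-bond donor, and the number still cannot be told apart from that of compound 1, so this place accepts a much larger group without a step beyond the scatter. Nothing available explains this result.

The compounds shown leave open whether the hydroxyl matters, since a plain pyrrolidin-1-ylcarbonyl does not appear among them. They also leave open whether an amine, a carboxylic acid or a longer chain at this place would produce a step beyond the scatter in either direction.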